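Cyclopropyl in place of cyclohexyl: an expected loss

This account rests on a few compounds, and the source may have more. Where it says the series, first, only, none or still open, it means among the compounds named here.

Compound 1 `O=C(O)c1ccccc1-c1ccc(CCc2ncc(CC3CCCCC3)[nH]2)cc1` gives 41 nM in an in vitro functional assay on cells for agonist activity at Bombesin receptor subtype-3 (Homo sapiens), read by luminescence and calcium flux (on this read-out higher numbers stand for an effect only at larger amounts of compound and lower numbers for an effect already at smaller amounts), the lowest number of the three measured compounds. Compound 2 `O=C(O)c1ccccc1-c1ccc(CCc2ncc(CC3CCCC3)[nH]2)cc1` gives 133 nM in the same assay, and compound 3 `O=C(O)c1ccccc1-c1ccc(CCc2ncc(Cc3ccc(Cl)cc3)[nH]2)cc1` gives 2290 nM. The step of a 3.2-fold higher number from compound 1 to compound 2 (0.51 log units; beyond the scatter) is modest, while a 56-fold higher number from compound 1 to compound 3 (1.75 log units; beyond the scatter) and a 17-fold higher number from compound 2 to compound 3 (1.24 log units; beyond the scatter) are both large, so any replacement of the cyclohexyl seen so far has cost potency.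

Compound 4 `O=C(O)c1ccccc1-c1ccc(CCc2ncc(CC3CC3)[nH]2)cc1` differs from compound 1 by cyclopropyl in place of cyclohexyl on a saturated chain carbon bound to an aromatic carbon. The measured step that bears on it most directly is a 3.2-fold higher number from compound 1 to compound 2 (0.51 log units; beyond the scatter), where cyclopentyl replaced cyclohexyl at the same place; the steps to compound 3 show how far the number can move when the cyclohexyl is exchanged for something less alike. Among the measured compounds shown here, no measured compound carries cyclopropyl, so the size of the step is uncertain.

A loss beyond the scatter is expected for compound 4, of the order of a 12-fold higher number from compound 1 to compound 4 (1.09 log units; beyond the scatter). Compound 4 is estimated at 500 nM, with a range from 150 nM to 2000 nM.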

Compound 4, half-maximal effective concentration: 1000 nM
For compound 4 the middle estimate is 2.0-fold (0.30 log units) below the measured one; the measured number falls inside the stated range.
By their numbers in this assay, from the lowest: compound 1; then compound 2; then compound 4; then compound 3.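

Among the saturated rings the number keeps rising as the ring gets smaller: going on from cyclopentyl to cyclopropyl gives a 7.5-fold higher number from compound 2 to compound 4 (0.88 log units; beyond the scatter), and the full change from cyclohexyl gives a 24-fold higher number from compound 1 to compound 4 (1.39 log units; beyond the scatter), so compounds 1, 2 and 4 follow ring size in this assay. The cyclopropyl compound still does better than the 4-chlorophenyl one, with a 2.3-fold lower number from compound 3 to compound 4 (0.36 log units; beyond the scatter), so compound 3 goes against any rule of ring size alone across all four compounds. Nothing available here accounts for how this position responds to these changes.

As far as these compounds go, it remains open whether a ring larger than cyclohexyl, such as cycloheptyl, or an open chain such as isobutyl, would continue this order. Also open, from the compounds shown here alone, is how a ring holding an amine nitrogen or an ether oxygen, as in piperidine or tetrahydropyran, would compare with cyclohexyl.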